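The compounds below may be only part of what the source reports. "The series", "measured", "known", "first", "only" and "open" are said of these compounds alone.

Measured compounds:
compound 1, `Cc1cc(Cl)cc(-c2ccnc3cc(CN4C(=O)C5CC5C4=O)sc23)c1C[C@H]1OCCN[C@@H]1C`: 210 nM
compound 2, `Cc1cc(Cl)cc(-c2ccnc3cc(CN4C(=O)C5C(C4=O)C5(C)C)sc23)c1NC1CCCNC1`: 33 nM
compound 3, `Cc1cc(Cl)cc(-c2ccnc3cc(CN4C(=O)CCC4=O)sc23)c1OC1CCNCC1`: 400 nM

All three were tested in an assay on RKO cells for inhibition of ubiquitin carboxyl-terminal hydrolase 7 (Homo sapiens), read by a luciferase reporter, with a stated time of 18 h; on this read-out higher numbers stand for an effect only at larger amounts of compound and lower numbers for an effect already at smaller amounts. Compound 1 stands second highest of the three numbers. Its nearest neighbour is compound 3, whose value in this assay lies within the scatter of the value of compound 1, so the two cannot be told apart. Compound 2 sits furthest away, and its number in this assay is lower than that of compound 1 by more than the scatter.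

Compound 4, `Cc1cc(Cl)cc(-c2ccnc3cc(CN4C(=O)C5CC5C4=O)sc23)c1O[C@@H]1CCNC[C@@H]1C`, has not yet been measured. It differs from compound 1 in one place: (3-methylpiperidin-4-yl)oxy in place of (3-methylmorpholin-2-yl)methyl on an aromatic carbon. Among the measured compounds shown here, no step between two measured compounds that differ in only one place is available, so the size of this step cannot be read from a precedent. What can be said is that compound 3, which also carries a piperidinyloxy group on that aromatic carbon, gives 400 nM in this assay, a number within the scatter of compound 1. On that basis compound 4 is expected to give about 160 nM in this assay, with a range from 50 nM to 500 nM. The estimated step of a 1.3-fold lower number from compound 1 to compound 4 (0.12 log units; within the scatter) is accordingly expected to stay within the scatter, with no clear direction.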

Compound 4, half-maximal effective concentration: 170 nM
Beside the measured number, compound 4's estimate is 1.1-fold (0.03 log units) below it, and the stated range covers the measured number.
By their numbers in this assay, from the lowest: compound 2; then compounds 4, 1 and 3 (each within the scatter of the next, the first and the last beyond it).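

In this assay, among the compounds shown here, a 1.2-fold lower number from compound 1 to compound 4 (0.09 log units; within the scatter) is the first step in which only the group on the aromatic carbon changes, here ortho to a methyl group and para to a chloro group, with the rest of the core of compound 1 held the same. The earlier compounds shown here differed from one another in more than one place, so they could not isolate this position. This step shows that (3-methylmorpholin-2-yl)methyl and (3-methylpiperidin-4-yl)oxy, which have the same heavy-atom count but place the oxygen differently, in the ring in one and as the link to the aromatic carbon in the other, cannot be told apart on this read-out, and no measurement shown here explains this.

From the compounds shown here alone, it remains open whether the same holds on this core for a link through an amine rather than through oxygen or a methylene, or for an open aminoalkyl chain in place of the six-membered ring. The part played by the ring methyl and its two defined stereocentres also remains open, as the unmethylated piperidin-4-yloxy group and the other stereoisomers of (3-methylpiperidin-4-yl)oxy do not appear on this core among the compounds shown.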